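The compounds below may be only part of what the source reports. "The series", "measured", "known", "first", "only" and "open" are said of these compounds alone.

Compound 1, `Cc1cccc(C)c1NC(=O)/C=C/C(=O)N1C/C(=C\c2ccccc2)C(=O)/C(=C/c2ccccc2)C1`, gives 7400 nM in a functional assay on CCRF-CEM cells (Homo sapiens) for cytotoxicity; on this read-out higher numbers stand for weaker inhibition and lower numbers for stronger inhibition.
Compound 2, `Cc1cccc(C)c1NC(=O)/C=C/C(=O)N1C/C(=C\c2ccc([N+](=O)[O-])cc2)C(=O)/C(=C/c2ccc([N+](=O)[O-])cc2)C1`, gives 230 nM in this assay.
Compound 3, `O=C(/C=C/C(=O)N1C/C(=C\c2ccccc2)C(=O)/C(=C/c2ccccc2)C1)Nc1ccccc1`, gives 1100 nM in this assay.

These three share one core and differ in the group carried on an amide-type nitrogen and in the rings at either end of the core. Compound 2 has the lowest number of the three, and its steps to compound 3 and to compound 1 both lie beyond the usual scatter. Between compound 1 and compound 3 the change is phenyl in place of 2,6-dimethylphenyl on an amide-type nitrogen, and it produced a 6.7-fold lower number from compound 1 to compound 3 (0.83 log units; beyond the scatter). How the core of compound 2 differs from the core of compound 1 is not broken down here.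

Compound 4, `O=C(/C=C/C(=O)N1C/C(=C\c2ccc([N+](=O)[O-])cc2)C(=O)/C(=C/c2ccc([N+](=O)[O-])cc2)C1)Nc1ccccc1`, has not yet been measured in this assay. It comes from compound 2 by the same change, (phenyl in place of 2,6-dimethylphenyl on an amide-type nitrogen), at the same place. Because that earlier step measured a 6.7-fold lower number from compound 1 to compound 3 (0.83 log units; beyond the scatter), the step expected for compound 4 is a 5.1-fold lower number from compound 2 to compound 4 (0.71 log units; beyond the scatter), with the caution that a single earlier example is a thin base. For compound 4 the estimate is 45 nM, expected to fall between 12 nM and 180 nM.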

Compound 4, half-maximal inhibitory concentration: 370 nM
Beside the measured number, compound 4's estimate is 8.2-fold (0.91 log units) below it; the measured number lies above the stated range.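

Putting phenyl in place of 2,6-dimethylphenyl on an amide-type nitrogen gave a 1.6-fold higher number from compound 2 to compound 4 (0.21 log units; within the scatter) in this assay, so on this core the change makes no measurable difference. The clear drop in number seen on the core of compound 1 therefore did not carry over to the core of compound 2, and the two cores respond differently to the same change: the same change on two cores in this assay, a 6.7-fold lower number (0.83 log units; beyond the scatter) from compound 1 to compound 3 and a 1.6-fold higher number (0.21 log units; within the scatter) from compound 2 to compound 4, 11-fold (1.03 log units) apart, beyond the scatter of two such steps
This shows that the size of the step cannot simply be moved from one core to the other in this series, but two pairs do not show why the steps differ or how the change would behave on any further core.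

The compounds shown leave open whether the nitro groups on the rings at either end of the core are what sets the two steps apart. Cores carrying an amine or a methoxy group in their place, each paired with both phenyl and 2,6-dimethylphenyl on the amide-type nitrogen, would help to test this.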